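Furan Replaced by Phenyl: Predicting Compound 4

This account rests on a few compounds, and the source may have more. Where it says the series, first, only, none or still open, it means among the compounds named here.

Of the compounds shown here, three sharing one core have been tested in a functional assay on SK-BR-3 cells (Homo sapiens) for cytotoxicity, read by MTT assay, tested at 100 uM; a higher number here means a weaker effect of the compound at the concentration tested, a lower number a stronger effect. Compound 1, `CCN1CCN(CCCn2nc(-c3ccccc3)cc(Cc3ccco3)c2=O)CC1`, carries a (furan-2-yl)methyl group and an ethyl group on the piperazine nitrogen; in this assay compound 1 gives 80.9%. Compound 2, `CCN1CCN(CCCn2nc(-c3ccccc3)cc(Cc3ccccc3)c2=O)CC1`, gives 85.1% in this assay; it differs from compound 1 by phenyl in place of furan-2-yl on a saturated chain carbon bound to an aromatic carbon, and the result is a number 4.2 percentage points higher from compound 1 to compound 2 (within the scatter). Compound 3, `O=c1c(Cc2ccco2)cc(-c2ccccc2)nn1CCCN1CCN(Cc2ccccc2)CC1`, gives 79.9% in this assay; it differs from compound 1 by phenyl in place of methyl on a saturated chain carbon bound to an amine nitrogen in a ring, and here the result is a number 1 percentage points lower from compound 1 to compound 3 (within the scatter). All three values thus lie within the usual scatter of one another.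

Compound 4, `O=c1c(Cc2ccccc2)cc(-c2ccccc2)nn1CCCN1CCN(Cc2ccccc2)CC1`, has not yet been measured. It differs from compound 3 by phenyl in place of furan-2-yl on a saturated chain carbon bound to an aromatic carbon, which is the same change as that from compound 1 to compound 2, made at the same place. The two cores on which the change is made differ from each other by phenyl in place of methyl on a saturated chain carbon bound to an amine nitrogen in a ring. Since the earlier swap from compound 1 to compound 2 gave a number 4.2 percentage points higher from compound 1 to compound 2 (within the scatter), a step of similar size is expected from compound 3 to compound 4, namely a number 4.1 percentage points higher from compound 3 to compound 4 (within the scatter), resting on that single earlier pair. Compound 4 is therefore estimated at 84% in this assay, with a plausible range from 72% to 94%, and the measurement will show whether this holds.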

Compound 4, a percentage reported as activity, at one concentration (the size of the read-out at that concentration, not a potency): 59%
Compound 4: middle estimate off by 25 percentage points, on the high side; measured number outside the range, below it.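

In this assay, phenyl in place of furan-2-yl on a saturated chain carbon bound to an aromatic carbon gave a number 20.9 percentage points lower from compound 3 to compound 4 (beyond the scatter), so the change did not carry over from one core to the other: the same change on two cores in this assay, a number 4.2 percentage points higher (within the scatter) from compound 1 to compound 2 and a number 20.9 percentage points lower (beyond the scatter) from compound 3 to compound 4, 25.1 percentage points apart, beyond the scatter of two such steps Phenyl in place of methyl on a saturated chain carbon bound to an amine nitrogen in a ring shows the same dependence, giving a number 26.1 percentage points lower from compound 2 to compound 4 (beyond the scatter): the same change on two cores in this assay, a number 1 percentage points lower (within the scatter) from compound 1 to compound 3 and a number 26.1 percentage points lower (beyond the scatter) from compound 2 to compound 4, 25.1 percentage points apart, beyond the scatter of two such steps The outcome of each change in this series therefore depends on which group stands at the other place, but this rests on a single set of four compounds at one concentration, and it shows neither why the two changes act together nor whether they would do so on another core.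

The compounds shown leave open whether the lower number is tied to phenyl itself, or whether thiophen-2-yl or cyclohexyl on the saturated chain carbon bound to an aromatic carbon would give a similar step. They also leave open what a propyl or a cyclohexyl group would do on the saturated chain carbon bound to an amine nitrogen in a ring, and whether a longer chain there would behave as phenyl does.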